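The source may report more compounds than this note shows. Statements on the series, on what has been measured and on what is new or still open speak of the compounds shown alone.

For the measured compounds named here, compound 1, with the structure `NCC(N)CCc1c[nH]c2ccc(F)cc12`, is the only one of three tested compounds to give a number in an assay on isolated protein (urine) for inhibition of Myeloperoxidase (Homo sapiens), with a stated time of 5 min; a lower number here means a stronger inhibitor, a higher number a weaker inhibitor: in this assay compound 1 gives 60 nM. Compound 2, with the structure `N#CCCCc1c[nH]c2ccc(C(=O)O)cc12`, is recorded in this assay as "not active" (no number reported). Compound 3, with the structure `NCCCc1c[nH]c2ccc(C(=O)O)cc12`, is likewise recorded in this assay as "not active" (no number reported). Going by the values given here, no measured pair differs in a single place, so no step size can be read from these three.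

Compound 4, with the structure `CCSCCc1c[nH]c2ccc(F)cc12`, has not yet been measured. It differs from compound 1 as follows: ethylsulfanyl in place of 1,2-diaminoethyl on a saturated chain carbon, two bonds along the chain from an aromatic carbon. The shared core of compound 1 and compound 4 is kept. Every other compound that lacks the 1,2-diaminoethyl chain gave no number, but neither compound 2 nor compound 3 differs from compound 1 in that chain alone.

The step of a 42-fold higher number from compound 1 to compound 4 (1.62 log units; beyond the scatter) is expected to go toward weaker inhibition, well beyond the usual scatter. Compound 4 is estimated at 2500 nM, within a range from 300 nM to 20000 nM.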

Compound 4, half-maximal inhibitory concentration: > 100 nM
Compound 4: only a limit was reported; the forecaster's own chance of this, stated with the estimate: 40%; the middle value lies beyond the limit too.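

Compound 4 is recorded in this assay as > 100 nM, which is a limit of the assay and not a number. For the compounds shown here, this gives the first comparison that differs in one place, on a saturated chain carbon, two bonds along the chain from an aromatic carbon: ethylsulfanyl in place of 1,2-diaminoethyl gives an at least 1.6-fold higher number from compound 1 to compound 4 (0.22 log units; that floor lies within the scatter). As far as these compounds go, that floor alone does not establish a real loss of inhibition from this change, and the true size of the step stays unknown, as the reading stops at a limit: the limit of > 100 nM in this assay, at which 1 of the 4 values shown sits.

From the compounds shown here alone, compound 1 gives 60 nM and it remains open whether a single amine on this chain keeps a value near that one. Compound 2 and compound 3 differ from compound 1 in more than one place, so their "not active" entries cannot show what the chain or the carboxylic acid does alone.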